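The compounds below may be only part of what the source reports. "The series", "measured", "known", "first", "only" and "open" are said of these compounds alone.

In a functional assay on T47D cells (Homo sapiens) for cytotoxicity, read by CCK-8 assay (on this read-out higher numbers stand for weaker inhibition and lower numbers for stronger inhibition), three compounds have been measured:

compound 1 `Oc1cccc(-c2cc(-c3ccccn3)cc(-c3ccccc3O)n2)c1` gives 2560 nM;
compound 2 `Oc1cccc(-c2cc(-c3ccccn3)cc(-c3cccc(O)c3)n2)c1` gives 1410 nM;
compound 3 `Oc1ccccc1-c1cc(-c2cccnc2)cc(-c2ccccc2O)n1` gives only a limit of the assay, > 50000 nM.

The change 3-hydroxyphenyl in place of 2-hydroxyphenyl on an aromatic carbon gave a 1.8-fold lower number from compound 1 to compound 2 (0.26 log units; within the scatter). Compound 3 sits at the limit of > 50000 nM in this assay, at which 1 of the 3 values shown sits. How the core of compound 3 differs from the core of compound 1 is not broken down here. Compound 4 `Oc1cccc(-c2cc(-c3cccnc3)cc(-c3ccccc3O)n2)c1` is not yet measured; it arises from compound 3 by 3-hydroxyphenyl in place of 2-hydroxyphenyl on an aromatic carbon. This is the same kind of change as from compound 1 to compound 2, though the surroundings differ: meta to a 2-hydroxyphenyl group and a pyridin-3-yl group here, meta to a 3-hydroxyphenyl group and a pyridin-2-yl group there. Because the earlier step of a 1.8-fold lower number from compound 1 to compound 2 (0.26 log units; within the scatter) stayed within the scatter, compound 4 is expected to move little, a number no higher from compound 3 to compound 4 (the limit leaves the size open). Compound 4 is therefore estimated at 50000 nM in this assay, between 15000 nM and 200000 nM, most likely again only a limit.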

Compound 4, half-maximal inhibitory concentration: 6230 nM
Beside the measured number, compound 4's estimate is 8.0-fold (0.90 log units) above it; the measured number lies below the stated range.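

In this assay, 3-hydroxyphenyl in place of 2-hydroxyphenyl did not carry the same size of effect from one core to the other: the same change on two cores in this assay, a 1.8-fold lower number (0.26 log units; within the scatter) from compound 1 to compound 2 and an at least 8.0-fold lower number (0.90 log units; beyond the scatter) from compound 3 to compound 4, at least 4.4-fold (0.64 log units) apart, beyond the scatter of two such steps

On the second core, the change gave an at least 8.0-fold lower number from compound 3 to compound 4 (0.90 log units; beyond the scatter). On these data alone, compound 3 is only a limit of the assay, > 50000 nM, so the true size of that gap remains unknown.

The two cores themselves differ by pyridin-3-yl in place of pyridin-2-yl, with a 2.4-fold higher number from compound 1 to compound 4 (0.39 log units; beyond the scatter), and these two pairs show that a step on one core need not predict the step on another, but not why the steps differ.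

As far as these compounds go, it remains open whether the same gap between cores would appear if an amine or a methoxy group replaced the hydroxyl on these rings.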